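Hydroxy(phenyl)methyl Exchanged for Phenoxy on a Shared Core

The compounds below may be only part of what the source reports. "The series", "measured", "known", "first", "only" and "open" are said of these compounds alone.

Compound 2 `CCS(=O)(=O)N(Cc1cccnc1)c1cccc(C(O)c2ccccc2)c1` is the only one of the three measured compounds to give a number in an assay on isolated protein with metabotropic glutamate receptor 2 (Homo sapiens) as the target (a higher number here means that more compound is needed for the effect, a lower number that less compound is needed), at 2500 nM. Compound 1 `CCS(=O)(=O)N(Cc1cccnc1)c1ccc(C(O)c2ccccc2)cc1` gives only a limit in this assay, > 30000 nM. Compound 3 `CCS(=O)(=O)N(Cc1cccnc1)c1ccc(C(F)c2ccccc2)cc1` likewise gives only a limit, > 30000 nM. The step from compound 1 to compound 3, a step that the two limits leave unreadable from compound 1 to compound 3, cannot be read, since both values sit at the limit of > 30000 nM in this assay, at which 2 of the 3 values shown sit.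

Compound 4 `CCS(=O)(=O)N(Cc1cccnc1)c1cccc(Oc2ccccc2)c1` differs from compound 2 by phenoxy in place of hydroxy(phenyl)methyl on an aromatic carbon. Within the data shown here, no measured step bears on this exchange, so the expectation rests on compound 2 alone. The step of a 1.8-fold higher number from compound 2 to compound 4 (0.26 log units; within the scatter) is estimated as a modest loss, not clearly beyond the scatter. Compound 4 is therefore expected near 4500 nM, between 1200 nM and 20000 nM.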

Compound 4, half-maximal effective concentration: 360 nM
For compound 4 the middle estimate is 13-fold (1.10 log units) above the measured one; the whole stated range lies above it.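

On this aromatic carbon, the exchange of hydroxy(phenyl)methyl for phenoxy gives in this assay a 6.9-fold lower number from compound 2 to compound 4 (0.84 log units; beyond the scatter), the first readable step among the compounds shown. It shows that the hydroxy(phenyl)methyl group and its hydrogen-bond donor are not needed for a measured number at this place, and that less compound is needed with phenoxy there. Nothing shown gives a cause for this step.

The compounds shown leave open whether a phenylamino or benzyl group at this place would match phenoxy. They also leave open how a longer chain between the two rings would behave.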